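Bromo in Place of Methoxy: An Expectation for Compound 3

The source may report more compounds than this note shows. Statements on the series, on what has been measured and on what is new or still open speak of the compounds shown alone.

compound 1 `O=C(CCCCC1CCSS1)NCc1cn(CCCCCOc2ccc3ccc(=O)oc3c2)nn1`: 78.5%
compound 2 `COc1ccc(-c2cc3ccc(OCCCCCn4cc(CNC(=O)CCCCC5CCSS5)nn4)cc3oc2=O)cc1`: 49%

In a functional assay on PC-12 cells (Rattus norvegicus) for cytotoxicity, read by MTT assay, with stated times of 3 h and 2 h, tested at 20 uM (on this read-out higher numbers stand for a stronger effect at the one concentration tested and lower numbers for a weaker effect), compound 1 gives 78.5%, and compound 2 gives 49%. Among the compounds with values here, compound 2 therefore stands lowest of the two numbers, with compound 1 as its only neighbour, separated by the step of a number 29.5 percentage points lower from compound 1 to compound 2 (beyond the scatter). Compound 3 `O=C(CCCCC1CCSS1)NCc1cn(CCCCCOc2ccc3cc(-c4ccc(Br)cc4)c(=O)oc3c2)nn1` differs from compound 2 in one place: bromo in place of methoxy on an aromatic carbon. Within the data shown here, no measured step exchanges one substituent on this 4-methoxyphenyl for another; the one step in hand puts the whole 4-methoxyphenyl in for hydrogen and so bears on the present change only distantly. With the group retained and only its terminal substituent exchanged, compound 3 is expected to stay near compound 2, with no step beyond the scatter and the estimated change written as a number 3 percentage points higher from compound 2 to compound 3 (within the scatter). Compound 3 is thus estimated at 52%, in a range from 35% to 70%.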

Compound 3, a percentage reported as activity, at one concentration (the size of the read-out at that concentration, not a potency): 52.3%
Compound 3: middle estimate off by 0.3 percentage points, on the low side, within the range that was stated.
By their numbers in this assay, from the lowest: compounds 2 and 3 (each within the scatter of the next); then compound 1.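

In this assay, within the data shown here, the first exchange at the end of the aryl group, on the aromatic carbon para to a large group, gives a number 3.3 percentage points higher from compound 2 to compound 3 (within the scatter), so this read-out does not separate methoxy from bromo at this place. Putting 4-bromophenyl in place of hydrogen gives a number 26.2 percentage points lower from compound 1 to compound 3 (beyond the scatter), so the drop first seen as a number 29.5 percentage points lower from compound 1 to compound 2 (beyond the scatter) is not confined to 4-methoxyphenyl but appears with both aryl groups shown. Nothing available explains either step.

On these data alone, it remains open whether an amine or a carboxylic acid at this carbon would also stay with compound 2 and compound 3, or would instead move the read-out toward compound 1. Also open, as far as these compounds go, is how a plain phenyl group, with no terminal substituent, would read against the hydrogen of compound 1.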